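The compounds below may be only part of what the source reports. "The series", "measured", "known", "first", "only" and "open" are said of these compounds alone.

Three measured compounds share one core and differ only in the aromatic group attached to the amide carbonyl. Compound 1 `O=C(Nc1cccc(/C=C/C(=O)c2nc3ccccc3[nH]2)c1)c1ccc(Br)cc1` gives 7000 nM in a functional assay on MCF7 cells (Homo sapiens) for antiproliferative activity, read by MTT assay, with a stated time of 48 h; a higher number here means a weaker inhibitor, a lower number a stronger inhibitor. Compound 2 `Cc1ccccc1C(=O)Nc1cccc(/C=C/C(=O)c2nc3ccccc3[nH]2)c1` gives 5870 nM in this assay, and compound 3 `Cc1cccc(C(=O)Nc2cccc(/C=C/C(=O)c3nc4ccccc4[nH]3)c2)c1` gives 5590 nM. The steps are small: a 1.2-fold lower number from compound 1 to compound 2 (0.08 log units; within the scatter), a 1.3-fold lower number from compound 1 to compound 3 (0.10 log units; within the scatter) and a 1.1-fold lower number from compound 2 to compound 3 (0.02 log units; within the scatter). Compound 3 holds the lowest number of the three, yet every step separating it from compound 1 and compound 2 sits within the scatter, so no ordering among them can be claimed.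

Compound 4 `COc1cccc(C(=O)Nc2cccc(/C=C/C(=O)c3nc4ccccc4[nH]3)c2)c1` is not yet measured. Its change from compound 3 is methoxy in place of methyl on an aromatic carbon of the ring bound to the carbonyl. Among the measured compounds shown here, the steps that bear on it are those that swapped groups on this same ring, and all of them stayed within the scatter. A step beyond the scatter is therefore not expected. Compound 4 is expected to give about 5500 nM in this assay, within a range from 2800 nM to 11000 nM. The estimated step is a 1.0-fold lower number from compound 3 to compound 4 (0.01 log units; within the scatter).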

Compound 4, half-maximal inhibitory concentration: 17800 nM
Compound 4: the middle estimate sits 3.2-fold (0.51 log units) below what was measured, outside the stated range (above it).
By their numbers in this assay, from the lowest: compounds 3, 2 and 1 (each within the scatter of the next); then compound 4.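

The ring bound to the carbonyl is less indifferent than the first three compounds suggested: in this assay, the switch from 3-methylphenyl to 3-methoxyphenyl gives a 3.2-fold higher number from compound 3 to compound 4 (0.50 log units; beyond the scatter), a modest step but the first beyond the scatter. The 3-methoxyphenyl group also stands apart from the other two groups on this ring, with a 3.0-fold higher number from compound 2 to compound 4 (0.48 log units; beyond the scatter) and a 2.5-fold higher number from compound 1 to compound 4 (0.41 log units; beyond the scatter), so the methoxy compound is separated from all three earlier compounds. Nothing available explains why this small exchange of methyl for methoxy, which adds a single oxygen, weakens the antiproliferative effect.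

As far as these compounds go, it remains open whether methoxy elsewhere on this ring would give a similar step. From the compounds shown here alone, it is also open whether a hydroxy group, an ethoxy group or an amine at this same place would read like methoxy or like methyl.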